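Swapping the terpene-like group for an aromatic ether

The compounds below may be only part of what the source reports. "The series", "measured", "known", "first", "only" and "open" are said of these compounds alone.

Compound 1 `CC1=CC[C@@H](C(C)(C)O[C@@H]2O[C@H](COC(=O)c3cc(O)c(O)c(O)c3)[C@@H](O)[C@H](O)[C@H]2O)CC1` gives 88.9% in a functional assay, read by spectrophotometry, with a stated time of 30 min, tested at 20 uM; a lower number here means a weaker effect, a higher number a stronger effect of the compound at the concentration tested.
Compound 2 `CC1=CC[C@H](C(C)(C)O[C@@H]2O[C@H](COC(=O)c3cc(O)c(O)c(O)c3)[C@@H](O)[C@H](O)[C@H]2O)CC1` gives 90.1% in this assay.

Compound 2 stands highest of the two numbers, with compound 1 nearest, a gap that lies within the scatter. Compound 3 `C=CCc1ccc(O[C@@H]2O[C@H](COC(=O)c3cc(O)c(O)c(O)c3)[C@@H](O)[C@H](O)[C@H]2O)c(OC)c1` differs from compound 2 by 4-allyl-2-methoxyphenyl in place of 1-methyl-1-(4-methylcyclohex-3-en-1-yl)ethyl on an oxygen on a saturated carbon. For the measured compounds named here, the only measured step, a number 1.2 percentage points higher from compound 1 to compound 2 (within the scatter), rests on the fact that compounds 1 and 2 differ only in the configuration as drawn and leaves the replaced group untouched, so it gives no guide to this swap. No step beyond the scatter is expected, so compound 3 is expected to move by a number 5.1 percentage points lower from compound 2 to compound 3 (within the scatter). Compound 3 is therefore estimated at 85%, between 60% and 100%.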

Compound 3, a percentage reported as activity, at one concentration (the size of the read-out at that concentration, not a potency): 95.2%
Estimate against measurement, compound 3: 10.2 percentage points below; the measured number falls inside the stated range.
By their numbers in this assay, from the lowest: compounds 1, 2 and 3 (each within the scatter of the next).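

At this position, on an oxygen on a saturated carbon, the aromatic 4-allyl-2-methoxyphenyl can replace the non-aromatic 1-methyl-1-(4-methylcyclohex-3-en-1-yl)ethyl while this assay stays within the scatter: the swap gives a number 5.1 percentage points higher from compound 2 to compound 3 (within the scatter) and a number 6.3 percentage points higher from compound 1 to compound 3 (within the scatter). So, among these compounds, this place accepts either ring type with no step beyond the scatter. Nothing shown explains this tolerance.

On these data alone, whether an amine or a carboxylic acid at this place would hold the read-out remains open. Each number also comes from a single concentration, so it gives the size of the effect at that concentration only, and whether any of these compounds has a stronger or weaker effect at other concentrations remains unknown.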